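Swapping the terminal amine ring on a kinase-type scaffold

The compounds below may be only part of what the source reports. "The series", "measured", "known", "first", "only" and "open" are said of these compounds alone.

Measured so far:
- compound 1, `COc1cc2c(Oc3ccc(NC(=O)c4nn(-c5ccccc5)c(=O)cc4C)cc3F)ccnc2cc1OCCCN1CCN(C)CC1`: 360 nM
- compound 2, `COc1cc2c(Oc3ccc(NC(=O)c4nn(-c5ccccc5C)c(=O)cc4C)cc3F)ccnc2cc1OCCCN1CCCCC1`: 3220 nM
- compound 3, `COc1cc2c(Oc3ccc(NC(=O)c4nn(-c5ccccc5C)c(=O)cc4C)cc3F)ccnc2cc1OCCCN1CCC(C)CC1`: 2260 nM

All three compounds were tested in a functional assay on NCI-H460 cells (Homo sapiens) for inhibition, read by MTT assay, with a stated time of 72 h; a higher number here means a weaker inhibitor, a lower number a stronger inhibitor. Compound 3 stands second highest of the three numbers: closest to compound 2, which gives 3220 nM, and farthest from compound 1, whose number lies beyond the scatter below it.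

Compound 4, `COc1cc2c(Oc3ccc(NC(=O)c4nn(-c5ccccc5C)c(=O)cc4C)cc3F)ccnc2cc1OCCCN1CCN(C)CC1`, has not yet been measured. It differs from compound 3 in one place: 4-methylpiperazin-1-yl in place of 4-methylpiperidin-1-yl on a saturated chain carbon, three bonds along the chain from an oxygen on an aromatic ring. Among the compounds with values here, no measured pair shows exactly this change. Within the data shown here, the only single step available, a 1.4-fold lower number from compound 2 to compound 3 (0.15 log units; within the scatter), concerns a methyl added to the amine ring and left the number within the scatter, so it hints that small edits at this end of the chain may matter little. Compound 4 carries the same 4-methylpiperazin-1-yl group as compound 1, and compound 1 gives 360 nM in this assay; yet the two also differ elsewhere, so the value of compound 1 can only suggest that this group is compatible with a low number.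

Weighing these, compound 4 is expected to come in at 1100 nM in this assay, with a plausible range from 350 nM to 3500 nM. This corresponds to an expected step of a 2.1-fold lower number from compound 3 to compound 4 (0.31 log units; beyond the scatter), leaning toward a lower number but with wide uncertainty.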

Compound 4, half-maximal inhibitory concentration: 3420 nM
Estimate against measurement, compound 4: 3.1-fold (0.49 log units) below, within the range that was stated.
By their numbers in this assay, from the lowest: compound 1; then compounds 3, 2 and 4 (each within the scatter of the next).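

In this assay, the change from 4-methylpiperidin-1-yl to 4-methylpiperazin-1-yl gives a 1.5-fold higher number from compound 3 to compound 4 (0.18 log units; within the scatter) and the change from piperidin-1-yl to 4-methylpiperazin-1-yl gives a 1.1-fold higher number from compound 2 to compound 4 (0.03 log units; within the scatter), so these three amine rings cannot be told apart on this core, even though the second ring nitrogen is new. Within the data shown here, the one large step lies elsewhere: methyl in place of hydrogen on an aromatic carbon gives a 9.5-fold higher number from compound 1 to compound 4 (0.98 log units; beyond the scatter) with the 4-methylpiperazin-1-yl group unchanged, which shows that this group alone does not secure the low number of compound 1 and that the value follows the aromatic methyl in this pair. Nothing measured on these compounds explains either result.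

As far as these compounds go, it remains open whether the amine ring also makes little difference on the core of compound 1, which lacks the aromatic methyl, or only on the methylated core. Among these compounds, a morpholine ring, a dimethylamino group or a longer chain at this position could test how far the tolerance extends, while a chlorine or methoxy group in place of the aromatic methyl could probe the one change that moved the number.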